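Shrinking a Pyrrolidine to an Azetidine on the Core

This account rests on a few compounds, and the source may have more. Where it says the series, first, only, none or still open, it means among the compounds named here.

Measured so far in a functional assay on HeLa cells (Homo sapiens) for inhibition, read by sulforhodamine B assay; a lower number here means a stronger inhibitor, a higher number a weaker inhibitor:
Compound 1 `COc1ccccc1NC1=CC(=O)c2c(nc3n2[C@H]2OC[C@@H](O)[C@H]2OC3)C1=O`: 7460 nM
Compound 2 `O=C1C(NC2CCCCC2)=CC(=O)c2c1nc1n2[C@H]2OC[C@@H](O)[C@H]2OC1`: > 16000 nM (a limit of the assay)
Compound 3 `O=C1C(N2CCCC2)=CC(=O)c2c1nc1n2[C@H]2OC[C@@H](O)[C@H]2OC1`: > 16000 nM (a limit of the assay)

Compound 1 is the only one of the three that returns a number in this assay. The result for compound 2 is only a limit of the assay. The result for compound 3 is likewise only a limit of the assay. Compound 3 therefore stands at the limit of > 16000 nM in this assay, at which 2 of the 3 values shown sit, and how it compares with compound 2 cannot be read: a step that the two limits leave unreadable from compound 2 to compound 3. Against compound 1, both an at least 2.1-fold higher number from compound 1 to compound 2 (0.33 log units; beyond the scatter) and an at least 2.1-fold higher number from compound 1 to compound 3 (0.33 log units; beyond the scatter) show a weakening of inhibition.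

Compound 4 `O=C1C(N2CCC2)=CC(=O)c2c1nc1n2[C@H]2OC[C@@H](O)[C@H]2OC1` differs from compound 3 in one place: azetidin-1-yl in place of pyrrolidin-1-yl on a double-bonded ring carbon. Going by the values given here, none of the measured steps alters the size of a saturated ring on this carbon, so none bears directly on the change; the two steps from compound 1 only show that compound 2 and compound 3 both reached the limit. No movement beyond the scatter is expected, and the reading for compound 4 is expected most likely to be a limit once more, a step that the limit leaves unreadable from compound 3 to compound 4. The estimate for compound 4 is 20000 nM, with a range from 8000 nM to 50000 nM.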

Compound 4, half-maximal inhibitory concentration: > 16000 nM
Compound 4 gave a limit, no number; the forecaster's own chance of this, stated with the estimate: 70%; the middle value is on the limit's open side.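

In this assay compound 4 also gives only a limit of the assay, > 16000 nM. Replacing pyrrolidin-1-yl with the smaller azetidin-1-yl on this double-bonded ring carbon therefore does not bring a number back, and the steps among compound 2, compound 3 and compound 4 cannot be read, so no order can be set among these three. Going by these compounds alone, the one readable step is an at least 2.1-fold higher number from compound 1 to compound 4 (0.33 log units; beyond the scatter), so the only number on this carbon still comes with the (2-methoxyphenyl)amino group, while the other three groups share one limit: the limit of > 16000 nM in this assay, at which 3 of the 4 values shown sit.

From the compounds shown here alone, it remains open whether the aromatic ring or the methoxy group of the (2-methoxyphenyl)amino group matters more for reaching a measurable value, a question that a plain phenylamino group could help to answer. Going by these compounds, it is also open whether any saturated ring on this carbon can give a number, and a morpholine or a piperazine would extend the comparison beyond rings with only carbon and one nitrogen.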